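The source may hold more compounds than are shown below. What is called first, only, known or untested is meant among the compounds shown, and "the series" means these compounds.

Measured so far:
compound 1, `CC(C)CS(=O)(=O)N(Cc1ccc(-c2cccc(F)c2F)cc1)[C@@H](C)C(=O)N[C@H](C#N)CC(N)=O` — 1820 nM
compound 2, `CCC[C@@H](C(=O)N[C@H](C#N)CC(N)=O)N(Cc1ccc(-c2cccc(F)c2F)cc1)S(C)(=O)=O` — 7750 nM

Both numbers come from an assay on isolated protein for inhibition of legumain (Homo sapiens), with stated times of 2 min and 60 min; on this read-out lower numbers stand for stronger inhibition and higher numbers for weaker inhibition. Compound 1 stands at the lower of the two numbers; compound 2 gives the higher one, and the gap between the two lies beyond the scatter. For the measured compounds named here, no single-point step between these two is recorded, since they differ in more than one place, so their pair shows only the two values themselves.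

Compound 3, `C[C@@H](C(=O)N[C@H](C#N)CC(N)=O)N(Cc1ccc(-c2cccc(F)c2F)cc1)S(=O)(=O)c1ccccc1`, is not yet measured. It is taken from compound 1 by one change:

phenyl in place of isobutyl on a sulfonyl sulfur

Nothing measured here tells what an aryl group in this position does, so the expected step is largely an extrapolation from compound 1 alone. The change keeps the sulfonamide intact and only exchanges the group on the sulfonyl sulfur, isobutyl for phenyl. Going by the values given here, the estimated step from compound 1 is a 1.2-fold lower number from compound 1 to compound 3 (0.08 log units; within the scatter), taken to be small and in no firm direction, with the range set wide because no comparable step is known. Compound 3 is therefore expected to give 1500 nM in this assay, between 400 nM and 6000 nM.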

Compound 3, half-maximal inhibitory concentration: > 10000 nM
Compound 3 gave a limit, no number; the forecaster's own chance of this, stated with the estimate: 5%; at least 6.6-fold (0.82 log units) between middle value and limit.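

Exchanging isobutyl for phenyl on the sulfonyl sulfur is not a neutral change in this assay: the record gives an at least 5.4-fold higher number from compound 1 to compound 3 (0.73 log units; beyond the scatter), so inhibition of legumain in this series responds to which group sits at this place, even with the sulfonamide and the rest of the core of compound 1 left intact. Compound 1 and compound 2 could not show this, as they differ in more than one place and their gap cannot be assigned to the sulfonyl substituent alone, whereas compound 1 and compound 3 differ only there. Compound 3 stands at a limit of the assay, so the step has a lower bound and no measured size: the limit of > 10000 nM in this assay, at which 1 of the 3 values shown sits.

The compounds shown leave open whether the ring itself or its aromatic character goes with the weaker inhibition, which cyclohexyl, a saturated six-membered ring of carbon, or benzyl on the sulfonyl sulfur would begin to separate. Also open, on these data alone, is how a longer alkyl chain compares with isobutyl at this place, and whether a phenyl ring carrying an amine or a carboxylic acid stays as weak as compound 3.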